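Swapping the cyclopropyl amide of compound 1 for a vinyl amide

The source may report more compounds than this note shows. Statements on the series, on what has been measured and on what is new or still open speak of the compounds shown alone.

Compound 1 `COc1ccc(CN(C(=O)C2CC2)c2cc(OC)c(OC)c(OC)c2)cc1O` gives the lowest number among the three compounds measured in a functional assay on MGC-803 cells (Homo sapiens) for inhibition, read by MTT assay, with a stated time of 48 h (a lower number here means a stronger inhibitor, a higher number a weaker inhibitor), with 59 nM. Compound 2 `COC(=O)c1cc(CNc2cc(OC)c(OC)c(OC)c2)ccc1OC` gives 49600 nM, and compound 3 `COc1ccc(CNc2cc(OC)c(OC)c(OC)c2)cc1[N+](=O)[O-]` gives 19400 nM. For the measured compounds named here, the only measured step between these compounds, a 2.6-fold lower number from compound 2 to compound 3 (0.41 log units; beyond the scatter), concerns a substituent on an aromatic carbon and not the amide group. Compound 4 `C=CC(=O)N(Cc1ccc(OC)c(O)c1)c1cc(OC)c(OC)c(OC)c1` keeps the shared core of compound 1 and differs only at the carbonyl carbon: vinyl in place of cyclopropyl on a carbonyl carbon. Going by the values given here, no measured pair shows a change at this carbonyl carbon, so the only guide is that both groups enter as small, uncharged, all-carbon units on the same position. Compound 4 is therefore expected to remain close to compound 1, with a step of a 1.2-fold higher number from compound 1 to compound 4 (0.07 log units; within the scatter) that is estimated to lie within the usual scatter. For compound 4 the expected value in this assay is 70 nM, estimated to lie between 20 nM and 250 nM.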

Compound 4, half-maximal inhibitory concentration: 62 nM
Estimate against measurement, compound 4: 1.1-fold (0.05 log units) above; the range from low to high includes it.
By their numbers in this assay, from the lowest: compounds 1 and 4 (each within the scatter of the next); then compound 3; then compound 2.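

In this assay, for the compounds shown here, the first measured change at this carbonyl carbon, vinyl in place of cyclopropyl, gives a 1.1-fold higher number from compound 1 to compound 4 (0.02 log units; within the scatter) and so falls within the scatter. In this one pair, the three-membered ring of cyclopropyl is therefore not required to keep the number at this level, since vinyl, with no ring and a double bond, gives a value that cannot be told apart from it. Nothing available explains why the two groups read alike.

Going by these compounds, whether the double bond matters remains open, and an ethyl group at the same carbon would bear on that, as would a longer chain such as butyl. On these data alone, it is equally open how an amine or a carboxylic acid on this carbonyl carbon would read, since both groups compared here contain carbon only.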